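Two methyls on the phenyl of compound 3: an expectation

The source may report more compounds than this note shows. Statements on the series, on what has been measured and on what is new or still open speak of the compounds shown alone.

Measured compounds:
compound 1 `COc1ccccc1CN(C)CCCCn1c(=O)oc2ccccc21` 594 nM
compound 2 `CN(CCCCn1c(=O)oc2ccccc21)Cc1cccc(Cl)c1` 302 nM
compound 3 `CN(CCCCn1c(=O)oc2ccccc21)Cc1ccccc1` 2.6 nM

Compound 3 stands lowest of the three numbers in an assay on membranes from liver for displacement of a labelled ligand from Sigma non-opioid intracellular receptor 1 (Rattus norvegicus), read by scintillation counting; a lower number here means a stronger inhibitor, a higher number a weaker inhibitor. Its nearest neighbour is compound 2: a 120-fold lower number from compound 2 to compound 3 (2.07 log units; beyond the scatter). Compound 1 lies furthest away: a 230-fold lower number from compound 1 to compound 3 (2.36 log units; beyond the scatter). Compound 1 and compound 2 sit close to each other: a 2.0-fold lower number from compound 1 to compound 2 (0.29 log units; within the scatter).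

Compound 4 `Cc1ccc(CN(C)CCCCn2c(=O)oc3ccccc32)c(C)c1` has not yet been measured. It differs from compound 3 in one place: 2,4-dimethylphenyl in place of phenyl on a saturated chain carbon bound to an amine nitrogen.

The two large steps bear on this change, since each of them replaces a group on the aromatic ring of compound 1 or compound 2 with hydrogen to reach the bare phenyl of compound 3, and each lowers the number to a degree well beyond the scatter. Compound 4 goes the other way, taking the bare phenyl of compound 3 to a ring carrying two methyl groups. For the measured compounds named here, no measured compound carries a methyl, and the groups removed in the measured steps sat elsewhere on the ring, so the size of the step is uncertain. Still, a large rise in the number is expected for compound 4: a 96-fold higher number from compound 3 to compound 4 (1.98 log units; beyond the scatter). Compound 4 is estimated at 250 nM, with a range from 30 nM to 2000 nM.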

Compound 4, inhibition constant: 239 nM
Compound 4: the middle estimate sits 1.0-fold (0.02 log units) above what was measured; the range from low to high includes it.
By their numbers in this assay, from the lowest: compound 3; then compounds 4, 2 and 1 (each within the scatter of the next, the first and the last beyond it).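

In this assay, methyl groups on the ring also raise the number, with a large step (a 92-fold higher number from compound 3 to compound 4 (1.96 log units; beyond the scatter)) that leaves compound 3 the strongest of the four and extends the preference for the bare phenyl to a third substituted ring. The substituted rings do not all read alike: one step is within the scatter (a 1.3-fold lower number from compound 2 to compound 4 (0.10 log units; within the scatter)), so the 2,4-dimethylphenyl and 3-chlorophenyl rings cannot be told apart, while another is modest but beyond it (a 2.5-fold lower number from compound 1 to compound 4 (0.40 log units; beyond the scatter)), so the 2,4-dimethylphenyl ring reads better than the 2-methoxyphenyl ring. No supporting evidence is available to explain these differences.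

Whether one methyl alone would account for the rise remains open, since both methyl groups enter together. Going by these compounds, how a fluoro group on the phenyl would read in this assay also remains open.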